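Aryl Substituent Changes on a Tricyclic Spiro Series

A few compounds are considered here, and "the series" means these few. Any claim that something is new, unique, unknown or untested is made for them only; others in the source may bear on it.

Among the compounds with values here, compound 2 `O=C1C2=C(C(=O)c3ncccc31)C1(CS2)NC(=O)N(c2ccccc2)C1=O` gives 1 nM in a functional assay on MCF7 cells (Homo sapiens) for antiproliferative activity, read by MTT assay, with a stated time of 96 h (on this read-out lower numbers stand for stronger inhibition and higher numbers for weaker inhibition), the lowest of the three numbers measured so far. Compound 1 `O=C1C2=C(C(=O)c3ncccc31)C1(CS2)NC(=O)N(c2ccc(Cl)cc2)C1=O` gives 4 nM, and compound 3 `O=C1C2=C(C(=O)c3ncccc31)C1(CS2)NC(=O)N(c2ccncc2)C1=O` gives 10 nM. Compound 4 `CN(C)c1ccc(N2C(=O)NC3(CSC4=C3C(=O)c3ncccc3C4=O)C2=O)cc1` is not yet measured; it differs from compound 2 by dimethylamino in place of hydrogen on an aromatic carbon. Within the data shown here, two measured steps bear on this change: a 4.0-fold lower number from compound 1 to compound 2 (0.60 log units; beyond the scatter), and a 10-fold higher number from compound 2 to compound 3 (1.00 log units; beyond the scatter). Both departures from the unsubstituted phenyl, the chloro of compound 1 and the pyridin-4-yl of compound 3, gave higher numbers, though neither is a dimethylamino group. A modest rise is therefore expected, about a 4.0-fold higher number from compound 2 to compound 4 (0.60 log units; beyond the scatter). Compound 4 is estimated at 4 nM, with a range from 1.5 nM to 12 nM.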

Compound 4, half-maximal inhibitory concentration: 10 nM
For compound 4 the middle estimate is 2.5-fold (0.40 log units) below the measured one; low and high end bracket the measured number.
By their numbers in this assay, from the lowest: compound 2; then compound 1; then compounds 3 and 4 (each within the scatter of the next).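

In this assay the dimethylamino group on this aromatic carbon gives a 10-fold higher number from compound 2 to compound 4 (1.00 log units; beyond the scatter), and replacing chloro at the same place gives a 2.5-fold higher number from compound 1 to compound 4 (0.40 log units; beyond the scatter), so both substituents shown here raise the number over the unsubstituted phenyl, dimethylamino more than chloro. Against pyridin-4-yl there is no change at the digits printed from compound 3 to compound 4 (within the scatter), so this read-out does not separate these two aryl groups. Nothing measured here accounts for these steps. As far as these compounds go, whether any group at this place keeps the number of compound 2 stays open. Fluoro, methoxy or a carboxylic acid there would test it.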